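Stilbene series: pendant aryl on the butenyl ether

The source may report more compounds than this note shows. Statements on the series, on what has been measured and on what is new or still open speak of the compounds shown alone.

Three members of the series have been run in a functional assay on HT-29 cells (Homo sapiens) for inhibition, read by MTT assay, with a stated time of 3 days; a lower number here means a stronger inhibitor, a higher number a weaker inhibitor. Compound 1 `COc1ccc(/C=C\c2cc(OC)c(OC)c(OC)c2)cc1OCc1ccccc1` gives 39000 nM. Compound 2 `COc1ccc(COc2cc(/C=C\c3cc(OC)c(OC)c(OC)c3)ccc2OC)cc1`, which carries methoxy in place of hydrogen on an aromatic carbon, gives 47000 nM; the step of a 1.2-fold higher number from compound 1 to compound 2 (0.08 log units; within the scatter). Compound 3 `COc1cccc(/C=C/CCCOc2cc(/C=C\c3cc(OC)c(OC)c(OC)c3)ccc2OC)c1`, with 4-(3-methoxyphenyl)but-3-en-1-yl in place of phenyl on a saturated chain carbon bound to an oxygen on an aromatic ring, gives 25000 nM. Compound 3 has the lowest of the three numbers, but the steps of a 1.6-fold lower number from compound 1 to compound 3 (0.19 log units; within the scatter) and a 1.9-fold lower number from compound 2 to compound 3 (0.27 log units; within the scatter) both lie within the scatter, so no order among the three can be claimed.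

Compound 4 `COCOc1ccc(/C=C/CCCOc2cc(/C=C\c3cc(OC)c(OC)c(OC)c3)ccc2OC)cc1` is not yet measured. It differs from compound 3 as follows: 4-(methoxymethoxy)phenyl in place of 3-methoxyphenyl on a double-bonded chain carbon bound to a double-bonded chain carbon. For the measured compounds named here, no measured step alters this pendant ring in the same way. The nearest points of comparison are the methoxy addition on an aromatic carbon, a 1.2-fold higher number from compound 1 to compound 2 (0.08 log units; within the scatter), and the exchange of one pendant arene for another, a 1.9-fold lower number from compound 2 to compound 3 (0.27 log units; within the scatter), neither of which moved the number beyond the scatter. On that basis the step of no change at the digits printed from compound 3 to compound 4 (within the scatter) is expected to stay within the scatter. Compound 4 is therefore estimated at 25000 nM, with a range from 10000 nM to 60000 nM.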

Compound 4, half-maximal inhibitory concentration: 7000 nM
Beside the measured number, compound 4's estimate is 3.6-fold (0.55 log units) above it; measured number outside the range, below it.
By their numbers in this assay, from the lowest: compound 4; then compounds 3, 1 and 2 (each within the scatter of the next).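

Notes on the pendant aryl: in this assay, the exchange of 3-methoxyphenyl for 4-(methoxymethoxy)phenyl on a double-bonded chain carbon bound to a double-bonded chain carbon gives a 3.6-fold lower number from compound 3 to compound 4 (0.55 log units; beyond the scatter) and is the first step in the series to pass beyond the scatter. The earlier steps shown here, including the exchange of one pendant group for another in a 1.9-fold lower number from compound 2 to compound 3 (0.27 log units; within the scatter), stayed within it, so the series now shows that the number responds to a change at this place, although the size of the step is modest. Nothing shown accounts for this step, and no supporting measurement bears on its cause.

The step replaces the 3-methoxy pattern with the 4-(methoxymethoxy) pattern in a single move, so the compounds shown cannot separate the effect of the substituent from that of where it sits on the ring. Also open, on these data alone, is whether the lower number would hold with a hydroxyl, an amine or a longer alkoxy chain on the same phenyl ring, and whether the same exchange would give a step of similar size on a shorter or longer linking chain.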